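Replacing the methoxy of compound 1 with hydrogen

This account rests on a few compounds, and the source may have more. Where it says the series, first, only, none or still open, it means among the compounds named here.

- Compound 1 `COC(=O)c1sc2cc(OC)ccc2c1Nc1cc(OC)c(OC)c(OC)c1` gives 10.3 nM
- Compound 2 `COC(=O)c1sc2ncccc2c1Nc1cc(OC)c(OC)c(OC)c1` gives 348 nM
- Compound 3 `CCOC(=O)c1sc2cc(C)ccc2c1Nc1cc(OC)c(OC)c(OC)c1` gives 1.5 nM

In a functional assay on SEM cells (Homo sapiens) for cytotoxicity, read by MTT assay, with a stated time of 72 h (a lower number here means a stronger inhibitor, a higher number a weaker inhibitor), compound 1 at 10.3 nM holds the middle place of the three, with compound 3 lower and compound 2 higher, both gaps beyond the scatter. Compound 4 `COC(=O)c1sc2ccccc2c1Nc1cc(OC)c(OC)c(OC)c1` carries hydrogen in place of methoxy on an aromatic carbon. Within the data shown here, no measured pair isolates this change. Compound 2 also lacks the methoxy and differs elsewhere too, sitting at 348 nM on the higher side. Compound 3 lacks it as well, with other differences, and lies on the lower side. A rise beyond the scatter is still expected, with an estimated step of a 3.4-fold higher number from compound 1 to compound 4 (0.53 log units; beyond the scatter) as the working figure. Compound 4 is estimated at 35 nM with an expected range of 8 nM to 150 nM around it.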

Compound 4, half-maximal inhibitory concentration: 179 nM
Beside the measured number, compound 4's estimate is 5.1-fold (0.71 log units) below it, and the stated range ends below it.
By their numbers in this assay, from the lowest: compound 3; then compound 1; then compounds 4 and 2 (each within the scatter of the next).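

In this assay, among these compounds, hydrogen in place of methoxy on this aromatic carbon reads as a 17-fold higher number from compound 1 to compound 4 (1.24 log units; beyond the scatter) and counts as a large loss, the first reading of this position with nothing else changed. The substituent here therefore matters, and a bare carbon does not keep the potency of compound 1. No measurement shown accounts for the size of the step.

As far as these compounds go, whether a hydroxyl, an amine or chlorine on this carbon would match methoxy remains open. So far, only methoxy and hydrogen can be compared here in a single change.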